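The source may hold more compounds than are shown below. What is called first, only, known or untested is meant among the compounds shown, and "the series" means these compounds.

Compound 1, `O=C1c2ccc(O)c(O)c2O[C@@H](c2cccc(O)c2O)[C@@H]1O`, in a functional assay on RAW264.7 cells (Rattus norvegicus) for inhibition, with RAW264.7 (Mus musculus) as the target, read by Griess assay, with stated times of 2 h and 16 h (a higher number here means a weaker inhibitor, a lower number a stronger inhibitor), gives > 100000 nM, a limit of the assay.
Compound 2, `COc1ccc2c(c1O)O[C@@H](c1cccc(O)c1O)[C@H](O)C2=O`, in this assay gives 88500 nM.
Compound 3, `COc1ccc2c(c1)C(=O)[C@@H](O)[C@H](c1cccc(O)c1O)O2`, in this assay gives > 100000 nM, likewise a limit.

The change hydrogen in place of methyl on an oxygen on an aromatic ring yields an at least 1.1-fold higher number from compound 2 to compound 1 (0.05 log units; that floor lies within the scatter), a step that runs into (the limit of > 100000 nM in this assay, at which 2 of the 3 values shown sit). How the core of compound 3 differs from that of compound 2 is not broken down here. Compound 4, `O=C1c2cc(O)ccc2O[C@@H](c2cccc(O)c2O)[C@@H]1O`, differs from compound 3 by hydrogen in place of methyl on an oxygen on an aromatic ring, the same change as between compound 2 and compound 1. For compound 4 the expected step is a step that the limit leaves unreadable from compound 3 to compound 4, resting on an at least 1.1-fold higher number from compound 2 to compound 1 (0.05 log units; that floor lies within the scatter) and on the fact that compound 3 already sits at the limit of > 100000 nM in this assay, at which 2 of the 3 values shown sit. Compound 4 is therefore estimated at 150000 nM, between 60000 nM and 500000 nM, most likely reported only as a limit.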

Compound 4, half-maximal inhibitory concentration: > 100000 nM
Compound 4: a limit, no number; the forecaster's own chance of this, stated with the estimate: 70%; the middle value does not contradict the limit.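

Compound 3 and compound 4 both stand at a limit, so no step between them can be read: the limit of > 100000 nM in this assay, at which 3 of the 4 values shown sit.

The compounds shown leave open whether methoxy to hydroxy changes inhibition at all on the core of compound 3.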